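The compounds below may be only part of what the source reports. "The series", "measured", "known", "first", "only" and "open" are said of these compounds alone.

Compound 1 `CCC1CCN(c2nc(C(C)(C)C)ccc2CNC(=O)C(C)c2ccc(NS(C)(=O)=O)c(F)c2)CC1` gives 0.1 nM in an assay on cells for antagonist activity at transient receptor potential cation channel subfamily V member 1 (Homo sapiens), read by FLIPR and calcium flux, with a stated time of 6 min (a lower number here means a stronger inhibitor, a higher number a weaker inhibitor), the lowest of the two numbers recorded. Within the data shown here, compound 2 `CC(C(=O)NCc1ccc(C(C)(C)C)nc1OCc1ccccc1)c1ccc(NS(C)(=O)=O)c(F)c1` gives 4.4 nM, and the single step between them, a 44-fold higher number from compound 1 to compound 2 (1.64 log units; beyond the scatter), is large. Compound 3 `CC(C(=O)NCc1ccc(C(C)(C)C)nc1SCc1ccccc1Cl)c1ccc(NS(C)(=O)=O)c(F)c1` differs from compound 1 by (2-chlorobenzyl)sulfanyl in place of 4-ethylpiperidin-1-yl on an aromatic carbon. Among the measured compounds shown here, only that one step bears on this change, and it swapped the same group for a benzyl-bearing substituent, so a step of similar size and direction is expected: a 50-fold higher number from compound 1 to compound 3 (1.70 log units; beyond the scatter). Compound 3 is therefore estimated at 5 nM, within 1.2 nM to 20 nM.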

Compound 3, inhibition constant: 3.8 nM
The estimate for compound 3 lay 1.3-fold (0.12 log units) above the measured number; the range from low to high includes it.
By their numbers in this assay, from the lowest: compound 1; then compounds 3 and 2 (each within the scatter of the next).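

In this assay, (2-chlorobenzyl)sulfanyl in place of 4-ethylpiperidin-1-yl also gives a large loss, a 38-fold higher number from compound 1 to compound 3 (1.58 log units; beyond the scatter), so this is no longer seen with benzyloxy alone. The two benzyl-bearing groups cannot be separated, a 1.2-fold lower number from compound 2 to compound 3 (0.06 log units; within the scatter), even though they differ in both the linking atom and the chlorine. No evidence bears on this result.

Going by these compounds, whether the ethyl group or the piperidine ring carries the advantage of compound 1 remains open, as does how a morpholine or a dimethylamino group would read here. The separate contributions of the sulfur and the chlorine also remain unresolved.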